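One Ring Substituent Swap from Compound 2 to Compound 4

A few compounds are considered here, and "the series" means these few. Any claim that something is new, unique, unknown or untested is made for them only; others in the source may bear on it.

Of the compounds shown here, three have been measured in a functional assay on BGC-823 cells (Homo sapiens) for antiproliferative activity, read by MTT assay, tested at 1 uM; on this read-out lower numbers stand for a weaker effect and higher numbers for a stronger effect at the one concentration tested. Compound 1 `COc1ccc(OC)c(/C=N/NC(=O)c2cc(OC)c(OC)c(OC)c2)c1` gives 0.1%, compound 2 `COc1ccc(C2OC(c3cc(OC)c(OC)c(OC)c3)=NN2C(C)=O)c(OC)c1` gives 6.3%, and compound 3 `COc1cc(C(=O)N/N=C/c2ccccc2C(F)(F)F)cc(OC)c1OC` gives 22.1%. Compound 2 stands second highest of the three numbers; its nearest neighbour is compound 1, a gap that lies within the usual scatter, while its furthest neighbour is compound 3, a gap that lies beyond it. Compound 4 `COc1cc(C2=NN(C(C)=O)C(c3ccc(F)cc3)O2)cc(OC)c1OC` has not yet been measured. It differs from compound 2 in one place: 4-fluorophenyl in place of 2,4-dimethoxyphenyl on a saturated ring carbon. Going by the values given here, no measured pair shows what such a change does, so no step in this assay beyond the scatter is expected in either direction. Compound 4 is estimated at 8%, with a range from 0% to 25%. The expected step of a number 1.7 percentage points higher from compound 2 to compound 4 (within the scatter) is small.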

Compound 4, a percentage reported as inhibition, at one concentration (the size of the read-out at that concentration, not a potency): -0.4%
Estimate against measurement, compound 4: 8.4 percentage points above; the measured number lies below the stated range.
By their numbers in this assay, from the lowest: compounds 4, 1 and 2 (each within the scatter of the next); then compound 3.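

Replacing 2,4-dimethoxyphenyl with 4-fluorophenyl on this saturated ring carbon gives, in this assay, a number 6.7 percentage points lower from compound 2 to compound 4 (within the scatter). Going by these compounds alone, this is the first measured pair at this position, and it shows that losing both methoxy groups and gaining a fluorine, with fewer heavy atoms and no hydrogen-bond acceptors on the ring, produces no change beyond the scatter. Nothing available offers an explanation for this result. Going by these compounds, what an amine or a carboxylic acid on this aromatic ring would do remains open, as does the separate contribution of each methoxy group and the fluorine.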